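The source may hold more compounds than are shown below. What is called first, only, known or untested is meant among the compounds shown, and "the series" means these compounds.

Measured so far:
compound 1 `CCN(CC)CCNc1cc(C)c2cc(NC(=O)c3ccc(Cl)c(Cl)c3)ccc2n1` — 3710 nM
compound 2 `CCN1CCN(c2cc(C)c3cc(NC(=O)c4ccccc4C)ccc3n2)CC1` — 29200 nM

In a functional assay on SK-BR-3 cells (Homo sapiens) for antiproliferative activity, read by MTT assay, with a stated time of 72 h (on this read-out higher numbers stand for weaker inhibition and lower numbers for stronger inhibition), compound 1 gives 3710 nM and holds the lower of the two numbers; compound 2 gives 29200 nM, a gap beyond the usual scatter. Among the measured compounds shown here, no pair differing in a single place has been measured, so no step size is known.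

Compound 3 `Cc1cc(N2CCCCC2)nc2ccc(NC(=O)c3ccc(Cl)c(Cl)c3)cc12` differs from compound 1 in one place: piperidin-1-yl in place of (2-(diethylamino)ethyl)amino on an aromatic carbon. For the measured compounds named here, with no comparable step on record, the expectation for this change is a moderate weakening, beyond the scatter but well short of the gap seen to compound 2. The step from compound 1 to compound 3 is expected to be a 2.4-fold higher number from compound 1 to compound 3 (0.38 log units; beyond the scatter). For compound 3 the estimate is 9000 nM, ranging from 2500 nM to 30000 nM.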

Compound 3, half-maximal inhibitory concentration: 42500 nM
Compound 3: middle estimate off by 4.7-fold (0.67 log units), on the low side; the whole stated range lies below it.
By their numbers in this assay, from the lowest: compound 1; then compounds 2 and 3 (each within the scatter of the next).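

Among the compounds shown here, with the rest of the core of compound 1 unchanged, placing piperidin-1-yl instead of (2-(diethylamino)ethyl)amino on the aromatic carbon next to the ring nitrogen gives a first measured step at this position in this assay (an 11-fold higher number from compound 1 to compound 3 (1.06 log units; beyond the scatter)). This position is therefore sensitive to the change, and the open-chain (2-(diethylamino)ethyl)amino group is the better of the two tested here. Nothing on hand accounts for the size of this step.

Going by these compounds, it remains open whether the ring itself or the loss of the open chain drives the step. A longer chain such as (3-(diethylamino)propyl)amino, or a morpholin-4-yl ring on the same carbon, would help separate these two readings.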